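The source may report more compounds than this note shows. Statements on the series, on what has been measured and on what is new or still open speak of the compounds shown alone.

Compound 1 `Cc1ccc2[nH]c(-n3[nH]c(C)c(Cc4ccccc4)c3=O)nc2c1` and compound 2 `Cc1ccc2[nH]c(-n3[nH]c(C)c(C)c3=O)nc2c1` share one core and differ in a single place: compound 1 carries phenyl on a saturated chain carbon bound to an aromatic carbon where compound 2 carries hydrogen. In a functional assay on DU-145 cells (Homo sapiens) for antiproliferative activity, read by WST assay, with a stated time of 7 days, tested at 10 uM (on this read-out higher numbers stand for a stronger effect at the one concentration tested and lower numbers for a weaker effect), compound 1 gives 81% and compound 2 gives 69%. Among the compounds with values here, compound 2 stands lowest of the two numbers measured, the nearest being compound 1, and the single measured step is a number 12 percentage points lower from compound 1 to compound 2 (beyond the scatter). Compound 3 `Cc1ccc2[nH]c(-n3[nH]c(C)c(Cc4ccc(Cl)cc4)c3=O)nc2c1` is not yet measured; against compound 2 the change is 4-chlorophenyl in place of hydrogen on a saturated chain carbon bound to an aromatic carbon. Within the data shown here, this change runs opposite to the one measured step and goes beyond it by the chlorine, so a number 12 percentage points lower from compound 1 to compound 2 (beyond the scatter) is the only step that bears on it. Read in reverse, that step points to a modest rise in this assay for compound 3 over compound 2, of roughly that size or somewhat more, with no measured compound to set the added chlorine apart. Compound 3 is therefore estimated at 84% in this assay, within 72% to 95%, an expected step of a number 15 percentage points higher from compound 2 to compound 3 (beyond the scatter).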

Compound 3, a percentage reported as inhibition, at one concentration (the size of the read-out at that concentration, not a potency): 90%
For compound 3 the middle estimate is 6 percentage points below the measured one, and the stated range covers the measured number.
By their numbers in this assay, from the lowest: compound 2; then compounds 1 and 3 (each within the scatter of the next).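

With 4-chlorophenyl in place of hydrogen on the saturated chain carbon bound to an aromatic carbon, this assay shows a number 21 percentage points higher from compound 2 to compound 3 (beyond the scatter) and so gives a second case, after compound 1, of an aromatic ring carried on this chain carbon standing beyond the scatter from the methyl compound. The chloro in place of hydrogen on an aromatic carbon gives a number 9 percentage points higher from compound 1 to compound 3 (within the scatter) and so cannot be told apart from the unsubstituted phenyl on this read-out, which means the rise over compound 2 holds with or without the chlorine. Nothing measured here gives a reason for either step.

The compounds shown leave open whether this chain carbon needs an aromatic ring at all, since a longer alkyl chain, an amine or a carboxylic acid in its place would test that directly. They also leave open whether a fluoro or methoxy group on the ring would separate from compound 1, and a read-out at a single concentration gives no potency order for any of these compounds.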